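Benzyl on the Aniline Nitrogen: Two Cores, One Change

A few compounds are considered here, and "the series" means these few. Any claim that something is new, unique, unknown or untested is made for them only; others in the source may bear on it.

Compound 1 `COc1cc(OC)n2cc(-c3ccc(N)cc3)nc2n1` carries a free aromatic amine on a dimethoxy-bearing bicyclic core. In a functional assay on HT-29 cells (Homo sapiens) for antiproliferative activity, read by MTT assay, with a stated time of 72 h (a lower number here means a stronger inhibitor of growth, a higher number a weaker inhibitor of growth), compound 1 gives > 100000 nM, which is a limit of the assay and not a number. Compound 2 `COc1cc(OC)n2cc(-c3ccc(NCc4ccccc4)cc3)nc2n1` differs from it by benzyl in place of hydrogen on a nitrogen on an aromatic ring. In this assay compound 2 gives > 100000 nM, again a limit rather than a number. The step that the two limits leave unreadable from compound 1 to compound 2 therefore cannot be read, since both ends rest at the limit of > 100000 nM in this assay, at which 2 of the 3 values shown sit.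

Compound 3 `Cc1ccc2nc(-c3ccc(N)cc3)cn2c1` places the same free aromatic amine on a different core; how the two cores differ is not broken down here. In this assay, among the compounds with values here, compound 3 gives 82900 nM, the only value in this set that is a number rather than a limit.

Compound 4 `Cc1ccc2nc(-c3ccc(NCc4ccccc4)cc3)cn2c1` has not yet been measured. It differs from compound 3 by benzyl in place of hydrogen on a nitrogen on an aromatic ring, which is the same change as that from compound 1 to compound 2, made at the same kind of place. Because the earlier instance of this change sits at the limit of > 100000 nM in this assay, at which 2 of the 3 values shown sit, at both ends, it offers no readable size to lean on. Within the data shown here, the expectation for the step from compound 3 to compound 4 is therefore a small one, a 1.1-fold higher number from compound 3 to compound 4 (0.04 log units; within the scatter), resting on the only number available, that of compound 3 at 82900 nM. Compound 4 is estimated at 90000 nM, with a range from 25000 nM to 300000 nM, and a real chance that this assay returns only a limit.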

Compound 4, concentration for 50% growth inhibition: 8800 nM
Beside the measured number, compound 4's estimate is 10-fold (1.01 log units) above it; the whole stated range lies above it.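

In this assay, putting benzyl in place of hydrogen on a nitrogen on an aromatic ring gives a 9.4-fold lower number from compound 3 to compound 4 (0.97 log units; beyond the scatter), so on this core the change has a readable effect that stands clear of the usual scatter of the measurement. Whether the same change does anything on the core of compound 1 cannot be read, because both ends of that step rest at a limit of the assay and not at a number: the limit of > 100000 nM in this assay, at which 2 of the 4 values shown sit. The series therefore holds a single readable instance of this change, and that instance neither shows that the effect carries from one core to the other nor shows that it fails to carry, so no rule about moving benzyl between these cores can be drawn from it.

The compounds shown leave open whether a methyl group or a longer chain such as phenethyl on that same nitrogen would move the number as benzyl does on this core. They also leave open whether a chlorine atom or a carboxylic acid on the benzyl ring would keep, deepen or lose the step.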